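This account rests on a few compounds, and the source may have more. Where it says the series, first, only, none or still open, it means among the compounds named here.

Compound 1 `Oc1ccc(-c2ccc(-c3ccc(-c4nc5ccccc5[nH]4)cc3)cc2)cc1` and compound 2 `COc1ccc(-c2ccc(-c3ccc(-c4nc5ccccc5[nH]4)cc3)cc2)cc1` share one core and differ only by methyl in place of hydrogen on an oxygen on an aromatic ring. In a functional assay on A549 cells (Homo sapiens) for inhibition, read by sulforhodamine B assay (on this read-out lower numbers stand for stronger inhibition of growth and higher numbers for weaker inhibition of growth), compound 1 gives 33100 nM. In this assay compound 2 gives 38100 nM, so that the step of a 1.2-fold higher number from compound 1 to compound 2 (0.06 log units; within the scatter) tells of no real change between the two. Compound 3 `Oc1ccc(-c2ccc(-c3ccc(-c4nc5c(O)cccc5[nH]4)cc3)cc2)cc1` is built on a different core, and the difference between the two cores is hydroxy in place of hydrogen on an aromatic carbon. In this assay compound 3 gives 170 nM; the step of a 190-fold lower number from compound 1 to compound 3 (2.29 log units; beyond the scatter) is by far the largest movement among the three measured compounds, and compound 3 stands beyond the scatter from both compound 1 and compound 2.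

Compound 4 `COc1ccc(-c2ccc(-c3ccc(-c4nc5c(O)cccc5[nH]4)cc3)cc2)cc1` has not been measured. It carries the core of compound 3 and differs from it by methyl in place of hydrogen on an oxygen on an aromatic ring. The place of this change reads the same, word for word, as the place of the change from compound 1 to compound 2, so the same change is now made on the other core. Among the measured compounds shown here, the one time this change was measured, between compound 1 and compound 2, the step of a 1.2-fold higher number from compound 1 to compound 2 (0.06 log units; within the scatter) lay within the scatter, and that is the only ground for any expectation here. The expected step is a 1.3-fold higher number from compound 3 to compound 4 (0.11 log units; within the scatter). Compound 4 is therefore expected to give about 220 nM in this assay, with the likely range running from 90 nM to 550 nM.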

Compound 4, concentration for 50% growth inhibition: 7690 nM
Estimate against measurement, compound 4: 35-fold (1.54 log units) below, outside the stated range (above it).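

In this assay, the change from hydroxy to methoxy does not carry over from one core to the other: on the core of compound 1 it made no real difference, but on the core of compound 3 it gives a 45-fold higher number from compound 3 to compound 4 (1.66 log units; beyond the scatter), and the two steps set side by side read: the same change on two cores in this assay, a 1.2-fold higher number (0.06 log units; within the scatter) from compound 1 to compound 2 and a 45-fold higher number (1.66 log units; beyond the scatter) from compound 3 to compound 4, 39-fold (1.59 log units) apart, beyond the scatter of two such steps Seen from the other direction, hydroxy in place of hydrogen on an aromatic carbon still lowers the number when the methoxy group is present, with a 5.0-fold lower number from compound 2 to compound 4 (0.69 log units; beyond the scatter), yet this step is much smaller than the one seen with the free hydroxy group: the same change on two cores in this assay, a 190-fold lower number (2.29 log units; beyond the scatter) from compound 1 to compound 3 and a 5.0-fold lower number (0.69 log units; beyond the scatter) from compound 2 to compound 4, 39-fold (1.59 log units) apart, beyond the scatter of two such steps The two changes are therefore not independent of each other in these four compounds, but the compounds do not show what lies behind this, and a single pair on each core gives no rule for other cores in the series.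

The compounds shown leave open whether the rise in the number belongs to methyl in particular or would follow any other group on that oxygen, such as an ethyl or a longer chain. They also leave open how an amine or a carboxylic acid in place of the hydroxy of the 4-hydroxyphenyl group would read on the core of compound 3.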